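Adding methyl to compound 2

The compounds below may be only part of what the source reports. "The series", "measured", "known", "first", "only" and "open" are said of these compounds alone.

compound 1 `COc1cc(C(=O)c2cn(-c3ccccc3)cc2-c2ccccc2C)cc(OC)c1OC` at 190 nM
compound 2 `COc1cc(C(=O)c2cn(-c3ccccc3)cc2-c2ccccc2[N+](=O)[O-])cc(OC)c1OC` at 49 nM
compound 3 `COc1cc(C(=O)c2cn(-c3ccccc3)cc2-c2cc(F)ccc2F)cc(OC)c1OC` at 230 nM

In a functional assay on MCF7 cells (Homo sapiens) for cytotoxicity, read by MTT assay, with a stated time of 96 h (a lower number here means a stronger inhibitor, a higher number a weaker inhibitor), compound 2 gives 49 nM as the lowest of the three numbers, with steps to both others beyond the scatter. For the measured compounds named here, compound 4 `COc1cc(C(=O)c2cn(-c3ccc(C)cc3)cc2-c2ccccc2[N+](=O)[O-])cc(OC)c1OC` differs from it by methyl in place of hydrogen on an aromatic carbon and no measured step makes this change. The available evidence speaks to size only: a 3.9-fold lower number from compound 1 to compound 2 (0.59 log units; beyond the scatter) and a 4.7-fold higher number from compound 2 to compound 3 (0.67 log units; beyond the scatter) were modest, and a 1.2-fold higher number from compound 1 to compound 3 (0.08 log units; within the scatter) stayed within the scatter, all at another place on the shared core. No step beyond the scatter is therefore expected, in either direction. The expected change is a 1.0-fold higher number from compound 2 to compound 4 (0.01 log units; within the scatter) on this estimate. The estimated value for compound 4 is 50 nM (expected range 18 nM to 140 nM).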

Compound 4, half-maximal inhibitory concentration: 65 nM
Estimate against measurement, compound 4: 1.3-fold (0.11 log units) below, within the range that was stated.
By their numbers in this assay, from the lowest: compounds 2 and 4 (each within the scatter of the next); then compounds 1 and 3 (each within the scatter of the next).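

In this assay, changing phenyl to 4-methylphenyl gives a 1.3-fold higher number from compound 2 to compound 4 (0.12 log units; within the scatter), the only step shown at this position, since compounds 1, 2 and 3 all keep the phenyl group. With the 2-nitrophenyl group in place, this position therefore takes a methyl without a change beyond the scatter. No measurement shown bears on why this is so.

On these data alone, it remains open whether an amine, a carboxylic acid or a longer chain at this position would also stay within the scatter. As far as these compounds go, whether methyl here behaves the same with the 2-methylphenyl group of compound 1 or the 2,5-difluorophenyl group of compound 3 is also open.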